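This account rests on a few compounds, and the source may have more. Where it says the series, first, only, none or still open, it means among the compounds named here.

Of the compounds shown here, three sharing one core have been measured in a functional assay on A549 cells (Homo sapiens) for inhibition, read by sulforhodamine B assay, with a stated time of 48 h; a higher number here means a weaker inhibitor of growth, a lower number a stronger inhibitor of growth. Compound 1 `COC(=O)[C@@]1(C)CCC=C2[C@@H]1CC[C@@H](C)[C@]2(C)Cc1c[nH]c2ccc(C)cc12` gives 17000 nM in this assay. Compound 2 `COC(=O)[C@@]1(C)CCC=C2[C@@H]1CC[C@@H](C)[C@]2(C)Cc1c(C)[nH]c2ccc(F)cc12` gives 15000 nM in this assay. Compound 3 `COC(=O)[C@@]1(C)CCC=C2[C@@H]1CC[C@@H](C)[C@]2(C)Cc1c(C)n(C(c2ccccc2)c2ccccc2)c2ccc(Cl)cc12` did not give a number in this assay; its result is only a limit, > 100000 nM. That limit is described by the limit of > 100000 nM in this assay, at which 1 of the 3 values shown sits, and it means that compound 3 stands at the weak end of what this assay can report, with no finite growth-inhibition concentration known for it.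

Compound 4 `Cc1c(C[C@]2(C)C3=CCC[C@](C)(C(=O)O)[C@H]3CC[C@H]2C)c2cc(Cl)ccc2n1C(c1ccccc1)c1ccccc1` is the next compound and has not yet been measured. It differs from compound 3 in one place: hydrogen in place of methyl on an oxygen next to a carbonyl group. Within the data shown here, no measured pair of compounds here shows this same change, so there is no directly comparable step to lean on. Given that the starting point is a limit, the step from compound 3 to compound 4 in this assay is expected to be a number no higher from compound 3 to compound 4 (the limit leaves the size open), and the most likely outcome is that compound 4 again reaches only a limit rather than a number. The estimate for compound 4 in this assay is 100000 nM, within a range from 30000 nM to 300000 nM.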

Compound 4, concentration for 50% growth inhibition: 9100 nM
Compound 4: the middle estimate sits 11-fold (1.04 log units) above what was measured; the measured number lies below the stated range.
By their numbers in this assay, from the lowest: compounds 4, 2 and 1 (each within the scatter of the next). At a limit, above all of these: compound 3.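

Swapping methyl for hydrogen on the oxygen next to a carbonyl group, which turns methoxycarbonyl into carboxy, gives an at least 10-fold lower number from compound 3 to compound 4 (1.04 log units; beyond the scatter) in this assay. Compounds 1, 2 and 3 all carry the methoxycarbonyl group, so they could say nothing about this position; this pair, alike everywhere else, shows that the change can give a finite reading, with compound 4 at 9100 nM. Compound 3 has only a limit and not a number, so the step gives a minimum size and its true size stays unknown: the limit of > 100000 nM in this assay, at which 1 of the 4 values shown sits.

On these data alone, the change is seen in this single pair, so it remains open whether the same swap would lower the numbers of compound 1 or compound 2, which carry a different set of groups elsewhere on the shared core. Only methoxycarbonyl and carboxy appear at this place, which leaves open how an amide, a hydroxymethyl group or a longer ester such as an ethyl ester would read in this assay.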